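The source may report more compounds than this note shows. Statements on the series, on what has been measured and on what is new or still open speak of the compounds shown alone.

Going by the values given here, in a functional assay on the whole organism with Mus musculus as the target, in the rotarod test (on this read-out lower numbers stand for an effect already at smaller amounts and higher numbers for an effect only at larger amounts of compound), compound 2 `CCC(=O)NCC(=O)N(C)c1ccc(Cl)cc1C(=O)c1ccccc1Cl` gives 36 mg/kg as the higher of the two numbers so far, and compound 1 `CC(NC(=O)CN)C(=O)N(C)c1ccc(Cl)cc1C(=O)c1ccccc1Cl` gives 8.5 mg/kg as the lower. Compound 3 `CN(C(=O)CNC(=O)c1ccccc1)c1ccc(Cl)cc1C(=O)c1ccccc1Cl` carries phenyl in place of ethyl on a carbonyl carbon, and phenyl in place of ethyl on a carbonyl carbon is the whole difference from compound 2. Among the compounds with values here, the one measured step of a 4.2-fold higher number from compound 1 to compound 2 (0.63 log units; beyond the scatter) is modest and beyond the scatter, but it is a different exchange and bears only loosely. Within the data shown here, no measured step covers this exchange, so in this assay no step beyond the scatter is expected, though one of similar modest size in either direction remains possible. The expected step of a 1.1-fold higher number from compound 2 to compound 3 (0.05 log units; within the scatter) is an estimate only. For compound 3 the estimated value is 40 mg/kg with an expected range from 15 mg/kg to 110 mg/kg in this read-out.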

Compound 3, dose for half-maximal effect: > 100 mg/kg
Compound 3 was reported as a limit; the forecaster's own chance of this, stated with the estimate: 10%; at least 2.5-fold (0.39 log units) between middle value and limit.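

In this assay, phenyl in place of ethyl on a carbonyl carbon gives an at least 2.7-fold higher number from compound 2 to compound 3 (0.44 log units; beyond the scatter), so this place does not tolerate every exchange. Benzamidomethyl in place of 1-(((aminomethyl)carbonyl)amino)ethyl gives an at least 11-fold higher number from compound 1 to compound 3 (1.07 log units; beyond the scatter), the largest step among the compounds shown. Compound 3 is reported only as a limit, so both steps are minimum sizes: the limit of > 100 mg/kg in this assay, at which 1 of the 3 values shown sits.

Open, from the compounds shown here alone, is whether a longer chain such as butyl on this carbonyl carbon stays nearer compound 2 or nearer compound 3. Also open, going by these compounds, is what aminomethyl does at this place without the methyl branch of compound 1.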